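Replacing an Aromatic Group with Methyl on a Sulfonyl Sulfur

The compounds below may be only part of what the source reports. "The series", "measured", "known", "first", "only" and "open" are said of these compounds alone.

Of the compounds shown here, three sharing one core have been measured in an ADME assay on HEK293 cells (Homo sapiens) for cytotoxicity, read by resazurin assay, with a stated time of 48 h; a lower number here means that less compound is tolerated, a higher number that more compound is tolerated. Compound 1 `Cc1ccc(S(=O)(=O)Nc2ccc3oc(-c4ccccc4)nc3c2)cc1` gives 75000 nM, compound 2 `C=Cc1ccc(S(=O)(=O)Nc2ccc3oc(-c4ccccc4)nc3c2)cc1` gives 53000 nM, and compound 3 `O=S(=O)(Nc1ccc2oc(-c3ccccc3)nc2c1)c1ccccc1O` gives 33000 nM. Compound 3 therefore stands clearly under compound 1, but it cannot be told apart from compound 2.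

Compound 4 `CS(=O)(=O)Nc1ccc2oc(-c3ccccc3)nc2c1` keeps the core and carries methyl in place of 2-hydroxyphenyl on a sulfonyl sulfur. Going by the values given here, all three measured compounds carry an aromatic group at this place, so no measured step shows this exchange directly. The nearest evidence comes from swaps between aromatic groups there: a 2.3-fold lower number from compound 1 to compound 3 (0.36 log units; beyond the scatter), and a 1.6-fold lower number from compound 2 to compound 3 (0.21 log units; within the scatter). Neither of these steps is large, and only the first lies beyond the scatter. Compound 4 also lacks the 2-hydroxyphenyl group, so it may resemble compound 1 and compound 2 more than compound 3 in this assay, though that rests on very few compounds. The expected change is therefore small and towards a higher number, a 1.8-fold higher number from compound 3 to compound 4 (0.26 log units; within the scatter). For compound 4 the estimate is 60000 nM, with an expected range from 30000 nM to 110000 nM.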

Compound 4, half-maximal cytotoxic concentration: > 100000 nM
Compound 4 gave a limit, no number (the forecaster's own chance of this, stated with the estimate: 25%); middle value at least 1.6-fold (0.22 log units) from the limit.
By their numbers in this assay, from the lowest: compounds 3, 2 and 1 (each within the scatter of the next, the first and the last beyond it). At a limit, above all of these: compound 4.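

In this assay compound 4 gives > 100000 nM, which is a limit of the assay and not a number. Going by these compounds alone, this is the first group without an aromatic ring at this place on the sulfonyl sulfur, and the exchange for methyl does not bring the number down: it gives an at least 3.0-fold higher number from compound 3 to compound 4 (0.48 log units; beyond the scatter), a step beyond the scatter, while an at least 1.8-fold higher number from compound 2 to compound 4 (0.27 log units; that floor lies within the scatter) and an at least 1.3-fold higher number from compound 1 to compound 4 (0.12 log units; that floor lies within the scatter) have floors that stay within the scatter, so only the first of these three steps is a firm separation. The true size of all three steps stays open because compound 4 sits at a limit: the limit of > 100000 nM in this assay, at which 1 of the 4 values shown sits.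

The compounds shown carry only methyl or an aromatic group on the sulfonyl sulfur, so it remains open whether a longer chain such as propyl, or a chain ending in an amine or a carboxylic acid, would also reach this limit. They also cannot separate an effect of methyl itself from the simple loss of the aromatic ring, and an ethyl group at this place would be a natural next comparison.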